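The source may report more compounds than this note shows. Statements on the series, on what has been measured and on what is new or still open speak of the compounds shown alone.

Measured so far:
- compound 1 `CN(C)c1ccc2nc(-c3cccc4ccccc34)[nH]c(=O)c2c1`: 100%
- compound 2 `Cc1ccc2nc(-c3cccc4ccccc34)[nH]c(=O)c2c1`: 4.1%

Going by the values given here, in an assay on isolated protein for inhibition of DNA topoisomerase 1 (Homo sapiens), with a stated time of 30 min, tested at 100 uM (on this read-out lower numbers stand for a weaker effect and higher numbers for a stronger effect at the one concentration tested), compound 2 gives the lower of the two numbers; the only other compound, compound 1, sits far above it, and the step of a number 95.9 percentage points lower from compound 1 to compound 2 (beyond the scatter) is the one change recorded so far.

Compound 3 `O=c1[nH]c(-c2cccc3ccccc23)nc2ccc(N3CCCCC3)cc12` is not yet measured. It differs from compound 2 in one place: piperidin-1-yl in place of methyl on an aromatic carbon. The change bears on the same aromatic carbon that the step from compound 1 to compound 2 touched, and there the loss of dimethylamino cost nearly the whole read-out. The entering group again carries a nitrogen bound to that carbon, so the relevant precedent points to a large rise rather than a change within the scatter.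

Compound 3 is therefore expected to recover most of the effect, an estimated step of a number 75.9 percentage points higher from compound 2 to compound 3 (beyond the scatter), giving an estimated 80% with a range of 40% to 100% in this assay.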

Compound 3, a percentage reported as inhibition, at one concentration (the size of the read-out at that concentration, not a potency): 100%
For compound 3 the middle estimate is 20 percentage points below the measured one; measured number inside the range.
By their numbers in this assay, from the lowest: compound 2; then compounds 1 and 3 (each within the scatter of the next).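

In this assay a second group bound through nitrogen now stands on this aromatic carbon: piperidin-1-yl in place of methyl gives a number 95.9 percentage points higher from compound 2 to compound 3 (beyond the scatter) and so the large effect is not confined to dimethylamino. Piperidin-1-yl in place of dimethylamino gives no change at the digits printed from compound 1 to compound 3 (within the scatter) and so this position accepts the six-membered non-aromatic ring without a loss in the read-out. No measured information accompanies these numbers to explain the response at this position.

On these data alone, whether nitrogen on this carbon is required remains open, and methoxy, with oxygen in that place, would test it. Compound 1 and compound 3 are compared at a single concentration, so any difference in the strength of their effect at other concentrations cannot be read, and morpholine or a primary amine would show how far the amine can vary.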